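The source may report more compounds than this note shows. Statements on the series, on what has been measured and on what is new or still open speak of the compounds shown alone.

Compound 1 `CN1CCN(c2nc(NCc3ccc(NC(=O)c4ccc(F)cc4)cc3)c3ccccc3n2)CC1`: 1800 nM
Compound 2 `CNc1nc(NCc2ccc(NS(=O)(=O)c3ccc(C)cc3)cc2)c2ccccc2n1`: 5800 nM

Both values come from a functional assay on HCT-116 cells (Homo sapiens) for inhibition, read by luminescence and resazurin assay, with a stated time of 3 days; on this read-out higher numbers stand for weaker inhibition and lower numbers for stronger inhibition. Compound 2, at 5800 nM, has the higher of the two numbers, and so the weaker inhibition. Its gap to compound 1 lies beyond the scatter.

Compound 3 `Cc1ccc(S(=O)(=O)Nc2ccc(CNc3nc(N4CCN(C)CC4)nc4ccccc34)cc2)cc1` keeps the rest of compound 2 and changes one group: 4-methylpiperazin-1-yl in place of methylamino on an aromatic carbon. This puts 4-methylpiperazin-1-yl in place of methylamino on an aromatic carbon, between two ring nitrogen atoms.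

Among the measured compounds shown here, no measured pair shows this change alone, so its size is uncertain. Compound 1 carries the same 4-methylpiperazin-1-yl group and gives 1800 nM, but it also differs from compound 3 elsewhere. A modest shift towards stronger inhibition in this assay therefore seems likely, perhaps within the scatter. The expected change is a 1.9-fold lower number from compound 2 to compound 3 (0.29 log units; within the scatter). Compound 3 is expected near 3000 nM, with an estimated range of 1100 nM to 7500 nM.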

Compound 3, half-maximal inhibitory concentration: > 20000 nM
Compound 3: no number, only a limit; the forecaster's own chance of this, stated with the estimate: 5%; middle value at least 6.6-fold (0.82 log units) away from the limit.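

In this assay compound 3 gives only a limit, not a number: the limit of > 20000 nM in this assay, at which 1 of the 3 values shown sits.

Putting 4-methylpiperazin-1-yl in place of methylamino, between two ring nitrogen atoms, brings an at least 3.4-fold higher number from compound 2 to compound 3 (0.53 log units; beyond the scatter), so with the (4-methylphenyl)sulfonyl group present, this position does not take the larger ring without a loss of inhibition. With 4-methylpiperazin-1-yl kept, exchanging (4-fluorophenyl)carbonyl for (4-methylphenyl)sulfonyl on the nitrogen brings an at least 11-fold higher number from compound 1 to compound 3 (1.04 log units; beyond the scatter), so 4-methylpiperazin-1-yl alone does not fix the level of inhibition.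

The limit leaves the true size of both steps open. Also open, going by these compounds, is whether a small amine such as dimethylamino, or a morpholin-4-yl ring, at this position would keep the inhibition seen with methylamino.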